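This account rests on a few compounds, and the source may have more. Where it says the series, first, only, none or still open, it means among the compounds named here.

Measured so far in this series:

- compound 1 `CC1(C)S[C@@H]2/C(=C\C(=O)c3ccc4ccccc4c3)C(=O)N2[C@H]1C(=O)OC(c1ccccc1)c1ccccc1`; in a functional assay on OE19 cells (Homo sapiens) for cytotoxicity, read by MTT assay, with a stated time of 48 h (a lower number here means a stronger inhibitor, a higher number a weaker inhibitor), compound 1 gives 19500 nM
- compound 2 `CC(=O)/C=C1\C[C@H]2SC(C)(C)[C@H](C(=O)OC(c3ccccc3)c3ccccc3)N2C1=O`; compound 2 reaches only the assay limit, > 100000 nM
- compound 3 `CC1(C)S[C@@H]2C/C(=C\C(=O)c3ccccc3)C(=O)N2[C@H]1C(=O)OC(c1ccccc1)c1ccccc1`; compound 3 gives 73300 nM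

Compound 1 carries the lowest of the two numbers, with compound 3 the nearest and higher. Going by the values given here, the only single-point step measured is an at least 1.3-fold lower number from compound 2 to compound 3 (0.13 log units; that floor lies within the scatter), a swap on the same carbonyl carbon; its size stays open because of the limit of > 100000 nM in this assay, at which 1 of the 3 values shown sits.

Compound 4 `CC1(C)S[C@@H]2/C(=C\C(=O)c3ccc([N+](=O)[O-])cc3)C(=O)N2[C@H]1C(=O)OC(c1ccccc1)c1ccccc1` differs from compound 1 by 4-nitrophenyl in place of naphthalen-2-yl on a carbonyl carbon. Among the compounds with values here, no measured step matches this change. Compound 3, which carries plain phenyl on that carbonyl, sits higher than compound 1, and 4-nitrophenyl is a phenyl bearing one substituent, so compound 4 is expected to land between the numbers of compound 1 and compound 3, giving an expected 2.1-fold higher number from compound 1 to compound 4 (0.31 log units; beyond the scatter). The estimate for compound 4 is 40000 nM, expected within 15000 nM to 100000 nM.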

Compound 4, half-maximal inhibitory concentration: 44100 nM
Compound 4: middle estimate off by 1.1-fold (0.04 log units), on the low side, and the stated range covers the measured number.
By their numbers in this assay, from the lowest: compound 1; then compounds 4 and 3 (each within the scatter of the next). At a limit, above all of these: compound 2.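

In this assay, 4-nitrophenyl in place of naphthalen-2-yl on this carbonyl carbon gives a 2.3-fold higher number from compound 1 to compound 4 (0.35 log units; beyond the scatter) as a step read in full, not as a floor. Going by these compounds alone, the number therefore responds to the group on this carbonyl carbon in the core of compound 1, whereas the only earlier step gave a floor within the scatter on another core. Nothing shown accounts for the step.

Plain phenyl on the core of compound 1 remains open. So does the effect of an amine or a carboxylic acid on that phenyl ring.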